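A carbamoyl swap in a flat cytotoxicity series

This account rests on a few compounds, and the source may have more. Where it says the series, first, only, none or still open, it means among the compounds named here.

In an ADME assay on HepG2 cells (Homo sapiens) for cytotoxicity, with a stated time of 72 h (on this read-out lower numbers stand for an effect already at smaller amounts and higher numbers for an effect only at larger amounts of compound), compound 1 (`Cc1cc(NC(=O)Nc2ccc(C(C)(C)C)cc2)c2ccccc2n1`) gives 17000 nM and compound 2 (`COC(=O)c1ccc(NC(=O)Nc2cc(C)nc3ccccc23)cc1`) gives 20000 nM while compound 3 (`Cc1cc(NC(=O)Nc2ccc(C(F)(F)F)cc2)c2ccccc2n1`) gives 23000 nM on the same read-out. Compound 3 stands level with both others, with a 1.4-fold higher number from compound 1 to compound 3 (0.13 log units; within the scatter) and a 1.2-fold higher number from compound 2 to compound 3 (0.06 log units; within the scatter) inside the scatter. Compound 4 (`Cc1cc(NC(=O)Nc2ccc(C(N)=O)cc2)c2ccccc2n1`) carries carbamoyl in place of trifluoromethyl on an aromatic carbon. On these data alone, at this same place a 1.2-fold higher number from compound 1 to compound 2 (0.07 log units; within the scatter) also stayed inside the scatter, so no step beyond the scatter is expected in this assay in either direction, although carbamoyl itself is untested. The expected step is a 1.1-fold higher number from compound 3 to compound 4 (0.04 log units; within the scatter) and remains an estimate. For compound 4 the estimated value is 25000 nM (range 12000 nM to 60000 nM).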

Compound 4, half-maximal effective concentration: > 25000 nM
Compound 4: only a limit was reported; the forecaster's own chance of this, stated with the estimate: 20%; the middle value lies on the limit itself.
By their numbers in this assay, from the lowest: compounds 1, 2 and 3 (each within the scatter of the next). At a limit, above all of these: compound 4.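

In this assay, compound 4 is reported only as a limit of the assay, not as a number: the limit of > 25000 nM in this assay, at which 1 of the 4 values shown sits. Carbamoyl at this position therefore gives only floors, an at least 1.0-fold higher number from compound 3 to compound 4 (0.03 log units; that floor lies within the scatter), an at least 1.2-fold higher number from compound 2 to compound 4 (0.09 log units; that floor lies within the scatter) and an at least 1.4-fold higher number from compound 1 to compound 4 (0.16 log units; that floor lies within the scatter), and each floor lies within the scatter. This extends the flat picture at this position to a group with a hydrogen-bond donor, but it no longer fixes the size of the step.

On these data alone, whether carbamoyl truly separates from the other three groups stays open. Also open, as far as these compounds go, is how a carboxylic acid or an amine at this place would read in this assay.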